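The source may report more compounds than this note shows. Statements on the series, on what has been measured and on what is new or still open speak of the compounds shown alone.

Measured so far:
compound 1 `O=C(NCc1ccc(S(=O)(=O)c2cccc(F)c2)cc1)c1cc2cnccc2[nH]1`: 5 nM
compound 2 `O=C(NCc1ccc(S(=O)(=O)c2ccccc2)cc1)c1ccc2cnccc2c1`: > 10000 nM
compound 3 `O=C(NCc1ccc(S(=O)(=O)c2ccccc2)cc1)c1cc(-c2cccnc2)no1`: 41 nM

In an assay for inhibition of Nicotinamide phosphoribosyltransferase (Homo sapiens), read by mass spectrometry, with stated times of 15 min and 30 min (a higher number here means a weaker inhibitor, a lower number a stronger inhibitor), compound 1 gives 5 nM, the lowest of the two numbers shown. Compound 3 gives 41 nM, and the gap to compound 1 lies beyond the scatter. For compound 2 this assay returns only a limit, > 10000 nM, which is the limit of > 10000 nM in this assay, at which 1 of the 3 values shown sits. Compound 4 `O=C(NCc1ccc(S(=O)(=O)c2ccc(F)cc2)cc1)c1cc2cnccc2[nH]1` differs from compound 1 in one place: 4-fluorophenyl in place of 3-fluorophenyl on a sulfonyl sulfur. For the measured compounds named here, no measured pair bears on this change, so the step is expected to be none beyond the scatter, and the estimated step of a 1.2-fold higher number from compound 1 to compound 4 (0.08 log units; within the scatter) is accordingly small. Compound 4 is expected at 6 nM, with a range from 2 nM to 20 nM.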

Compound 4, half-maximal inhibitory concentration: 17 nM
Compound 4: middle estimate off by 2.8-fold (0.45 log units), on the low side; measured number inside the range.
By their numbers in this assay, from the lowest: compound 1; then compound 4; then compound 3. At a limit, above all of these: compound 2.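

Moving the fluorine is not a neutral change in this assay: replacing 3-fluorophenyl with 4-fluorophenyl on the sulfonyl sulfur gives a 3.4-fold higher number from compound 1 to compound 4 (0.53 log units; beyond the scatter). For the compounds shown here, the earlier compounds held no pair differing in one place, so this is the first direct reading at this position, and it shows that the assay separates two compounds with the same atoms. Nothing measured here accounts for the difference.

From the compounds shown here alone, it remains open how a chlorophenyl or a methoxyphenyl group on the sulfonyl sulfur would compare with these two fluorophenyl groups. Going by these compounds, whether the same step would appear on a different core also remains open.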